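Replacing the 1H-pyrrol-2-yl group of compound 1

The source may report more compounds than this note shows. Statements on the series, on what has been measured and on what is new or still open speak of the compounds shown alone.

Compound 1 `CCOC(=O)/C=C/C=C/C=C/c1ccc[nH]1`: 3670 nM
Compound 2 `CCOC(=O)/C=C/C=C/C=C/C=C/c1cccn1C`: > 10000 nM

Going by the values given here, in a functional assay on CCRF-CEM cells (Homo sapiens) for cytotoxicity, with a stated time of 72 h (on this read-out higher numbers stand for weaker inhibition and lower numbers for stronger inhibition), compound 1 gives 3670 nM, the only exact number so far. For compound 2, > 10000 nM is a limit of the assay and not a number. Compound 3 `CCOC(=O)/C=C/C=C/C=C/c1nccs1` has not yet been measured. It carries 1,3-thiazol-2-yl in place of 1H-pyrrol-2-yl on a double-bonded chain carbon bound to a double-bonded chain carbon. Among the compounds with values here, no measured pair of compounds shows what such a swap does in this assay, so the expectation is loose and starts from compound 1 at 3670 nM. A small shift toward weaker inhibition, within the usual scatter, is expected. The estimated step is a 1.4-fold higher number from compound 1 to compound 3 (0.13 log units; within the scatter). For compound 3, the estimated value is 5000 nM, with an expected range from 1800 nM to 13000 nM.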

Compound 3, half-maximal inhibitory concentration: 4500 nM
The estimate for compound 3 lay 1.1-fold (0.05 log units) above the measured number, and the stated range covers the measured number.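

Going by these compounds alone, the swap of 1H-pyrrol-2-yl for 1,3-thiazol-2-yl is the first change on a double-bonded chain carbon bound to a double-bonded chain carbon that can be read in this assay, and it gives a 1.2-fold higher number from compound 1 to compound 3 (0.09 log units; within the scatter). This place therefore accepts a change from a ring with 1 hydrogen-bond donor and 0 hydrogen-bond acceptors to one with 0 hydrogen-bond donors and 2 hydrogen-bond acceptors, with no difference that stands clear of the scatter. Compound 2 offers only a limit and not a number, and it differs from compound 1 in more than one place, so it gives no step to set beside this one: the limit of > 10000 nM in this assay, at which 1 of the 3 values shown sits.

A single swap cannot show which changes at this place would move the number beyond the scatter. Going by these compounds, what a phenyl ring, an amine or a carboxylic acid would do here remains open.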